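Hydroxyl on the amine side chain: compound 3 to compound 4

The source may report more compounds than this note shows. Statements on the series, on what has been measured and on what is new or still open speak of the compounds shown alone.

The shared core is held constant across the series; the changes measured so far sit on the aryl group of the urea. Compound 1 `CC(C)N(CCN(C(=O)Nc1cccc(Br)c1)C1CC[C@]2(c3cccc(C#N)c3)CC2C1)C(C)C` gives 5.7 nM in a functional assay for antagonist activity at melanin-concentrating hormone receptor 1 (Homo sapiens); a higher number here means a weaker inhibitor, a lower number a stronger inhibitor. Compound 2 `CC(C)N(CCN(C(=O)Nc1cccc(C#N)c1)C1CC[C@]2(c3cccc(C#N)c3)CC2C1)C(C)C` gives 7.6 nM in this assay, and a 1.3-fold higher number from compound 1 to compound 2 (0.12 log units; within the scatter). Compound 3 `CC(C)N(CCN(C(=O)Nc1cc(Cl)nc(Cl)c1)C1CC[C@]2(c3cccc(C#N)c3)CC2C1)C(C)C` gives 2.4 nM in this assay, the lowest number of the three: a 2.4-fold lower number from compound 1 to compound 3 (0.38 log units; beyond the scatter) and a 3.2-fold lower number from compound 2 to compound 3 (0.50 log units; beyond the scatter).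

Compound 4 `CC(C)N(CCN(C(=O)Nc1cc(Cl)nc(Cl)c1)C1CC[C@]2(c3cccc(C#N)c3)CC2C1)[C@@H](C)CO` keeps the urea aryl group of compound 3 and differs only on the amine side: hydroxy in place of hydrogen on a saturated chain carbon, two bonds along the chain from an amine nitrogen. Within the data shown here, none of the measured steps touches this part of the molecule; all three concern the aryl group on the urea nitrogen, and their sizes, within the scatter for the first and modest beyond it for the other two, carry no information about a change on the amine chain. There is thus no measured basis for predicting a step in either direction, and the working expectation for compound 4 in this assay is a number close to that of compound 3, with a 1.5-fold higher number from compound 3 to compound 4 (0.16 log units; within the scatter) expected to stay within the scatter. Compound 4 is estimated at 3.5 nM, with a range of 1.2 nM to 10 nM.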

Compound 4, inhibition constant: 1.6 nM
Estimate against measurement, compound 4: 2.2-fold (0.34 log units) above, within the range that was stated.
By their numbers in this assay, from the lowest: compounds 4 and 3 (each within the scatter of the next); then compounds 1 and 2 (each within the scatter of the next).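

In this assay, the hydroxy in place of hydrogen on a saturated chain carbon, two bonds along the chain from an amine nitrogen, gives a 1.5-fold lower number from compound 3 to compound 4 (0.18 log units; within the scatter), so compound 3 and compound 4 cannot be told apart in this read-out. Among these compounds, this is the first reading on the amine side of the series, since the earlier steps all concern the aryl group on the urea nitrogen, and it shows that exchanging isopropyl for 1-(hydroxymethyl)ethyl, with its added oxygen, hydrogen-bond donor and hydrogen-bond acceptor, leaves the number within the scatter on this 2,6-dichloropyridin-4-yl urea. No supporting measurement is available that would account for this outcome.

Among the compounds shown here, the single step leaves open how far this position accepts other groups: a methoxy, a primary amine, a carboxylic acid or a longer chain such as 2-hydroxyethyl on the same nitrogen could each move the number in either direction. It also leaves open whether the 1-(hydroxymethyl)ethyl group gives a similar step when the urea carries 3-bromophenyl or 3-cyanophenyl instead.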